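The source may hold more compounds than are shown below. What is called first, only, known or untested is meant among the compounds shown, and "the series" means these compounds.

Compound 1 `O=C(Nc1cccc(-n2cc(-c3ccncc3)c(-c3cc(O)cc(Cl)c3)n2)c1)Nc1ccc(Cl)c(C(F)(F)F)c1` in a functional assay on Malme-3M cells (Homo sapiens) for inhibition, read by sulforhodamine B assay, with a stated time of 48 h, tested at 100 uM (on this read-out higher numbers stand for a weaker effect at the one concentration tested and lower numbers for a stronger effect), gives -91%.
Compound 2 `O=C(Nc1cccc(-n2cc(-c3ccncc3)c(-c3cc(O)cc(Cl)c3)n2)c1)Nc1ccc(Cl)c(Cl)c1` gives -45%.
Compound 3 `COc1cc(Cl)cc(-c2nn(-c3cccc(NC(=O)Nc4cc(C(F)(F)F)cc(C(F)(F)F)c4)c3)cc2-c2ccncc2)c1` gives -39%.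

Compound 3 stands highest of the three: its number lies within the scatter of that of compound 2 and beyond the scatter from that of compound 1. Compound 4 `COc1cc(Cl)cc(-c2nn(-c3cccc(NC(=O)Nc4cccc(C(F)(F)F)c4)c3)cc2-c2ccncc2)c1` differs from compound 3 in one place: hydrogen in place of trifluoromethyl on an aromatic carbon. Within the data shown here, the one measured step, a number 46 percentage points higher from compound 1 to compound 2 (beyond the scatter), likewise removes a trifluoromethyl from an aromatic carbon, though it brings in chloro rather than hydrogen and sits in a different surround, so it is only a loose guide. On that basis compound 4 is expected to give a somewhat higher number than compound 3, a step of a number 29 percentage points higher from compound 3 to compound 4 (beyond the scatter). The estimate for compound 4 in this assay is -10%, with a range from -50% to 30%.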

Compound 4, a percentage reported as activity, at one concentration (the size of the read-out at that concentration, not a potency): -26%
Compound 4: the middle estimate sits 16 percentage points above what was measured, and the stated range covers the measured number.
By their numbers in this assay, from the lowest: compound 1; then compounds 2 and 3 (each within the scatter of the next); then compound 4.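

Replacing trifluoromethyl by hydrogen, on an aromatic carbon meta to a trifluoromethyl group, gives a number 13 percentage points higher from compound 3 to compound 4 (beyond the scatter) in this assay as a modest step. Here hydrogen enters rather than chloro, so this position is seen with the group simply gone, and compound 4 still gives a negative number at -26% with one trifluoromethyl left on that ring.

Going by these compounds, whether a methyl, a methoxy or a nitrile on this carbon would fall nearer compound 3 or compound 4 stays open. Nothing available here accounts for the size of this step.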